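Swapping an Amine Substituent for a Carbamate in 5-HT6 Ligands

A few compounds are considered here, and "the series" means these few. Any claim that something is new, unique, unknown or untested is made for them only; others in the source may bear on it.

Compound 1 `O=S(=O)(c1cccc(F)c1)c1ccc2c(c1)CCC[C@H]2CN1CC(O)C1`: 0.1 nM
Compound 2 `COCCNC[C@@H]1CCCc2cc(S(=O)(=O)c3cccc(F)c3)ccc21`: 0.251 nM

Compound 2 gives the higher of the two numbers in an assay on isolated protein for displacement of a labelled ligand from 5-hydroxytryptamine receptor 6 (Homo sapiens); a lower number here means a stronger inhibitor, a higher number a weaker inhibitor; its nearest neighbour is compound 1, and the step of a 2.5-fold higher number from compound 1 to compound 2 (0.40 log units; beyond the scatter) is a modest one. Compound 3 `COC(=O)NC[C@@H]1CCCc2cc(S(=O)(=O)c3cccc(F)c3)ccc21` is the next structure to be measured. It differs from compound 2 by methoxycarbonyl in place of 2-methoxyethyl on an amine nitrogen. Within the data shown here, the only measured step, a 2.5-fold higher number from compound 1 to compound 2 (0.40 log units; beyond the scatter), exchanges one amine-bearing group for another and leaves an amine nitrogen in place, so it bears on this change only loosely. Among the measured compounds shown here, no measured step alters the amine nitrogen itself. The expected direction is therefore a higher number, and the step from compound 2 is estimated to be larger than the measured one, at a 120-fold higher number from compound 2 to compound 3 (2.08 log units; beyond the scatter). Compound 3 is estimated to give 30 nM in this assay, with a range from 3 nM to 300 nM.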

Compound 3, inhibition constant: 1.59 nM
Beside the measured number, compound 3's estimate is 19-fold (1.28 log units) above it; the whole stated range lies above it.
By their numbers in this assay, from the lowest: compound 1; then compound 2; then compound 3.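

In this assay, the step of a 6.3-fold higher number from compound 2 to compound 3 (0.80 log units; beyond the scatter) shows that placing a carbonyl-bearing group directly on the amine nitrogen can raise the number, which the earlier exchange of one amine-bearing group for another could not show. Set against the 3-hydroxyazetidin-1-yl group of compound 1, the (methoxycarbonyl)amino group gives a 16-fold higher number from compound 1 to compound 3 (1.20 log units; beyond the scatter), a large step at this saturated chain carbon. Even so, compound 3 remains in the low nanomolar range at 1.59 nM, so this position accepts the methoxycarbonyl group with a loss but without abolishing binding. Nothing available explains these differences.

As far as these compounds go, it remains open whether an acetyl group or an ethoxycarbonyl group on the same amine nitrogen would give a number close to that of compound 3. From the compounds shown here alone, it is also open whether a simple methyl group there would stay closer to compound 2.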